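A few compounds are considered here, and "the series" means these few. Any claim that something is new, unique, unknown or untested is made for them only; others in the source may bear on it.

Of the compounds shown here, three built on one shared core have so far been tested in a functional assay on MCF7 cells (Homo sapiens) for cytotoxicity, read by sulforhodamine B assay, with a stated time of 48 h; on this read-out lower numbers stand for stronger inhibition and higher numbers for weaker inhibition. Compound 1 `C=CCOc1c(Cl)cc(Cl)cc1C(=O)c1cccnc1` gives 85000 nM, compound 2 `O=C(c1cccnc1)c1cccc(Cl)c1O` gives 26700 nM, and compound 3 `O=C(c1cccnc1)c1cc(Cl)ccc1O` gives 29000 nM. Compound 3 therefore stands second highest of the three numbers: its nearest neighbour is compound 2, which sits within the usual scatter of it, while compound 1 lies furthest away, with a higher number beyond the scatter. Compound 4 `O=C(c1cccnc1)c1cc(Cl)cc(Cl)c1O` has not yet been measured in this assay. It differs from compound 3 by a single change: chloro in place of hydrogen on an aromatic carbon. For the measured compounds named here, no comparable step among the measured compounds is available, so only a modest shift, if any beyond the scatter, is expected, and a 1.5-fold lower number from compound 3 to compound 4 (0.16 log units; within the scatter) is the step anticipated. Compound 4 is accordingly estimated at 20000 nM, with a range from 8000 nM to 50000 nM.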

Compound 4, half-maximal inhibitory concentration: 29600 nM
Compound 4: the middle estimate sits 1.5-fold (0.17 log units) below what was measured; the range from low to high includes it.
By their numbers in this assay, from the lowest: compounds 2, 3 and 4 (each within the scatter of the next); then compound 1.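

Placing chloro in place of hydrogen on an aromatic carbon, ortho to a hydroxy group, gives a 1.0-fold higher number from compound 3 to compound 4 (0.01 log units; within the scatter). Counting the other chloro of compound 4 as the new one gives the same picture, with a 1.1-fold higher number from compound 2 to compound 4 (0.04 log units; within the scatter), so neither single chloro step separates the compounds in this assay. The allyl group on the oxygen does mark a difference, with hydrogen in its place giving a 2.9-fold lower number from compound 1 to compound 4 (0.46 log units; beyond the scatter).

Nothing measured here accounts for these results. From the compounds shown here alone, whether an amine or a carboxylic acid in place of either chloro, or a longer chain on the oxygen, would shift the number remains open.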